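Bromo to methyl in a closely spaced series

The compounds below may be only part of what the source reports. "The series", "measured", "known", "first", "only" and "open" are said of these compounds alone.

Values in an ADME assay on RAW264.7 cells (Mus musculus) for cytotoxicity, read by MTT assay, with a stated time of 48 h; a higher number here means that more compound is tolerated, a lower number that less compound is tolerated:
Compound 1 (`Fc1ccc(NC(=S)N/N=C\c2ccnc3ccccc23)cc1`) gives 45900 nM
Compound 2 (`S=C(N/N=C\c1ccnc2ccccc12)Nc1ccc(Cl)cc1`) gives 63500 nM
Compound 3 (`S=C(N/N=C\c1ccnc2ccccc12)Nc1ccc(Br)cc1`) gives 53500 nM

These three numbers sit close together. Compound 3 lies within the scatter of both others, with a 1.2-fold higher number from compound 1 to compound 3 (0.07 log units; within the scatter) on one side and a 1.2-fold lower number from compound 2 to compound 3 (0.07 log units; within the scatter) on the other. The remaining step, a 1.4-fold higher number from compound 1 to compound 2 (0.14 log units; within the scatter), is also within the scatter.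

Compound 4 (`Cc1ccc(NC(=S)N/N=C\c2ccnc3ccccc23)cc1`) has not yet been measured. It carries methyl in place of bromo on an aromatic carbon, para to a large group, so 4-bromophenyl becomes 4-methylphenyl: methyl in place of bromo on an aromatic carbon.

All three measured steps swap one halogen for another, and none brings in a methyl. They therefore bear on this change only indirectly. Still, among these compounds, changing this group has not moved the number in this assay beyond the scatter, so no larger move is expected here, though the range should stay generous for an untested group. The expected step is a 1.1-fold lower number from compound 3 to compound 4 (0.03 log units; within the scatter), which means no real change in either direction.

For compound 4 the estimated value is 50000 nM, with an expected range from 28000 nM to 90000 nM.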

Compound 4, half-maximal cytotoxic concentration: 50500 nM
Compound 4: the middle estimate sits 1.0-fold (0.00 log units) below what was measured; low and high end bracket the measured number.
By their numbers in this assay, from the lowest: compounds 1, 4, 3 and 2 (each within the scatter of the next).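

With methyl, this position now carries something other than a halogen, and the picture in this assay does not change: the swap from bromo gives a 1.1-fold lower number from compound 3 to compound 4 (0.03 log units; within the scatter), the swap from chloro gives a 1.3-fold lower number from compound 2 to compound 4 (0.10 log units; within the scatter), and the swap from fluoro gives a 1.1-fold higher number from compound 1 to compound 4 (0.04 log units; within the scatter). All three steps lie within the scatter, so the four compounds cannot be put in any real order, and the earlier finding, which rested on halogen swaps alone, now extends to a carbon group on this aromatic carbon. Nothing shown explains why this assay gives the same reading across these groups, so the result stands as an observation without a known cause.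

The compounds shown cover only fluoro, chloro, bromo and methyl at this position, so it remains open whether an amine, a carboxylic acid or a longer chain would also stay within the scatter in this assay. All four compounds also share the same core, which leaves open whether the same swaps would behave alike on a different one.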